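From phenylsulfonyl to (4-nitrophenyl)sulfonyl on compound 3

The source may hold more compounds than are shown below. What is called first, only, known or untested is meant among the compounds shown, and "the series" means these compounds.

In a functional assay on SMMC-7721 cells (Homo sapiens) for cytotoxicity, read by MTT assay, with a stated time of 24 h (a higher number here means a weaker inhibitor, a lower number a stronger inhibitor), compound 3 `O=C1/C(=C/c2ccncc2)CN(S(=O)(=O)c2ccccc2)C/C1=C\c1ccccc1C(F)(F)F` gives 6540 nM. Compound 1 `CN1C/C(=C\c2ccncc2)C(=O)/C(=C/c2ccccc2C(F)(F)F)C1` gives 4100 nM, and these two values lie within the scatter of each other. Compound 2 `O=C1/C(=C/c2cccnc2)CN(S(=O)(=O)c2ccc([N+](=O)[O-])cc2)C/C1=C\c1ccccc1C(F)(F)F` gives 15900 nM, a higher number than compound 3 and beyond the scatter from it.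

Compound 4 `O=C1/C(=C/c2ccncc2)CN(S(=O)(=O)c2ccc([N+](=O)[O-])cc2)C/C1=C\c1ccccc1C(F)(F)F` departs from compound 3 at one place, turning phenylsulfonyl into (4-nitrophenyl)sulfonyl: nitro in place of hydrogen on an aromatic carbon, para to a large group.

Within the data shown here, the only measured step that bears on this is a 1.6-fold higher number from compound 1 to compound 3 (0.20 log units; within the scatter), with phenylsulfonyl in place of methyl on an amine nitrogen in a ring. It concerns the same nitrogen substituent but does not test the nitro group, so it gives no direct measure of this change. The nearest hint is compound 2, which carries the (4-nitrophenyl)sulfonyl group and gives 15900 nM, although it also differs from compound 4 elsewhere in its structure.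

A modest move toward a weaker inhibitor is therefore expected, namely a 1.5-fold higher number from compound 3 to compound 4 (0.18 log units; within the scatter). Compound 4 is estimated at 10000 nM, with an expected range from 4000 nM to 22000 nM.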

Compound 4, half-maximal inhibitory concentration: > 20000 nM
Compound 4 was reported as a limit; the forecaster's own chance of this, stated with the estimate: 5%; at least 2.0-fold (0.30 log units) between middle value and limit.
By their numbers in this assay, from the lowest: compounds 1 and 3 (each within the scatter of the next); then compound 2. At a limit, above all of these: compound 4.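

In this assay compound 4 is reported only as a limit (> 20000 nM), so the steps to it are floors and its true value remains unfixed: the limit of > 20000 nM in this assay, at which 1 of the 4 values shown sits.

Even as a floor, nitro in place of hydrogen on an aromatic carbon, para to a large group, gives an at least 3.0-fold higher number from compound 3 to compound 4 (0.48 log units; beyond the scatter). Among these compounds, this is the first sign that the phenyl ring of the phenylsulfonyl group responds to substitution, since replacing methyl with the unsubstituted phenylsulfonyl group gave only a 1.6-fold higher number from compound 1 to compound 3 (0.20 log units; within the scatter). With the nitro group in place, the full change on the ring nitrogen gives an at least 4.8-fold higher number from compound 1 to compound 4 (0.68 log units; beyond the scatter), so this nitrogen substituent can shift the number beyond the scatter once the phenyl ring carries nitro.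

The swap of pyridin-3-yl for pyridin-4-yl remains unresolved, as an at least 1.2-fold higher number from compound 2 to compound 4 (0.09 log units; that floor lies within the scatter) gives a floor that cannot separate the two rings. Also open, going by these compounds, is whether the response belongs to nitro specifically or would extend to an amine, a methoxy group or a chlorine on the same aromatic carbon.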